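The source may hold more compounds than are shown below. What is called first, only, known or untested is meant among the compounds shown, and "the series" means these compounds.

Compound 1 `CN(C)CCCn1c(CN(C)C2CCCc3cccnc32)nc2ccccc21`: 16800 nM
Compound 2 `CN(Cc1nc2cccc(C(=O)NCCCCN)c2[nH]1)C1CCCc2cccnc21`: > 20000 nM
Compound 3 `CN(Cc1nc2cccc(CN)c2[nH]1)C1CCCc2cccnc21`: > 20000 nM

All three were tested in an ADME assay on HOS cells (Homo sapiens) for cytotoxicity; on this read-out lower numbers stand for higher toxicity in this test and higher numbers for lower toxicity in this test. Compound 2 reads > 20000 nM, which is a limit of the assay and not a number. It shares that standing with one other compound, as the limit of > 20000 nM in this assay, at which 2 of the 3 values shown sit, shows. Among the compounds with values here, compound 1 gives 16800 nM, the only true number in the set.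

Compound 4 `CN(Cc1nc2cccc(N3CCNCC3)c2[nH]1)C1CCCc2cccnc21` has not yet been measured. It places piperazin-1-yl in place of (4-aminobutyl)carbamoyl on an aromatic carbon.

One measured step replaces the same group of compound 2: a step that the two limits leave unreadable from compound 2 to compound 3. That step has no readable size, so it gives no direction. Compound 3 reads > 20000 nM, likewise a limit. On that ground, no step beyond the usual scatter is expected in this assay, and compound 4 may well report only a limit too. The expected step is a number no higher from compound 2 to compound 4 (the limit leaves the size open). For compound 4 the estimated value is 20000 nM, with an expected range of 9000 nM to 40000 nM.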

Compound 4, half-maximal cytotoxic concentration: > 20000 nM
Compound 4: a limit, no number (the forecaster's own chance of this, stated with the estimate: 65%); the middle value lies on the limit itself.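

Compound 4 reads > 20000 nM, a limit of the assay and not a number. Within the data shown here, no step from compound 2 or compound 3 to compound 4 can be read, since all three are limits. The compounds shown leave open whether these three truly differ in this assay.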